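The compounds below may be only part of what the source reports. "The series", "measured", "known", "first", "only" and "open" are said of these compounds alone.

Compound 3 (`COc1cc2ncnc(-n3nc(-c4ccccn4)nc3N)c2cc1OCc1ccccc1`): 8600 nM
Compound 1 (`Nc1nc(-c2ccccn2)nn1-c1ncnc2ccccc12`): > 40000 nM
Compound 2 (`COc1cc2ncnc(Nc3ccccn3)c2cc1OC`): > 40000 nM

Of the compounds shown here, three have been measured in an assay on MCF7 cells for inhibition of Serine-protein kinase ATM (Homo sapiens), read by immunofluorescence, with a stated time of 1 h; on this read-out higher numbers stand for weaker inhibition and lower numbers for stronger inhibition. Compound 3 is the only one with a numbered result; in this assay compound 3 gives 8600 nM. For compound 1 the assay reports only a limit, > 40000 nM. For compound 2 the assay likewise reports only a limit, > 40000 nM. That limit is the point at which two of the three results sit, as described in the limit of > 40000 nM in this assay, at which 2 of the 3 values shown sit, so compound 3 stands apart from the other two simply by having a number at all.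

Compound 4 (`CCN(CC)C(=O)COc1cc2c(-n3nc(-c4ccccn4)nc3N)ncnc2cc1OC`) has not yet been measured in this assay. It differs from compound 3 in one place: diethylcarbamoyl in place of phenyl on a saturated chain carbon bound to an oxygen on an aromatic ring. In words, diethylcarbamoyl takes the place of phenyl on a saturated chain carbon bound to an oxygen on an aromatic ring. For the measured compounds named here, no measured pair of compounds shows a change of this kind, so there is no step from which to read its size.

For compound 4 a small step toward stronger inhibition is expected, a 1.7-fold lower number from compound 3 to compound 4 (0.24 log units; within the scatter), which may fall within the scatter of repeated measurements. Compound 4 is accordingly expected to give 5000 nM, within a range from 1500 nM to 25000 nM.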

Compound 4, half-maximal inhibitory concentration: 5300 nM
Estimate against measurement, compound 4: 1.1-fold (0.03 log units) below; measured number inside the range.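

In this assay, for the compounds shown here, the swap gives a 1.6-fold lower number from compound 3 to compound 4 (0.21 log units; within the scatter), so the two compounds read alike, and this is the first measured look at what the group on this chain carbon does. Phenyl brings a six-membered aromatic ring of carbon only and no hydrogen-bond acceptor, while diethylcarbamoyl brings no ring and one hydrogen-bond acceptor, so in this pair the aromatic ring at this place is not needed to keep the read-out where it stands, even though the groups have little in common beyond their similar size in heavy atoms. Nothing shown here gives a reason why two such different groups read alike.

As far as these compounds go, whether a carboxylic acid, a primary amine or a longer chain at this same place would also read alike stays open, and so does whether any group here can move the number beyond the scatter. A single pair also cannot tell whether this swap would behave the same way on a different core, or with other groups on the rest of the molecule.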